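Phenyl in place of methoxy: compound 2 to compound 3

This account rests on a few compounds, and the source may have more. Where it says the series, first, only, none or still open, it means among the compounds named here.

Compound 1 `C/C(=N\Nc1nc(-c2ccc([N+](=O)[O-])cc2)cs1)c1ccc(Cl)c(Cl)c1` reads > 50000 nM in an ADME assay on J774 cells (Mus musculus) for cytotoxicity, read by resazurin assay, with a stated time of 72 h (a higher number here means that more compound is tolerated, a lower number that less compound is tolerated), a limit and not a number. Compound 2 `COc1ccc(-c2csc(N/N=C(\C)c3ccc(Cl)c(Cl)c3)n2)cc1` also stands at a limit, > 50000 nM. Compound 3 `C/C(=N\Nc1nc(-c2ccc(-c3ccccc3)cc2)cs1)c1ccc(Cl)c(Cl)c1` carries phenyl in place of methoxy on an aromatic carbon. For the measured compounds named here, the only measured step, a step that the two limits leave unreadable from compound 1 to compound 2, gives no size to carry over, and the series so far shows only (the limit of > 50000 nM in this assay, at which 2 of the 2 values shown sit). No shift beyond the scatter is therefore expected in this assay, and the expected step is a number no higher from compound 2 to compound 3 (the limit leaves the size open). The estimate for compound 3 is 50000 nM, with an expected range of 18000 nM to 100000 nM.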

Compound 3, half-maximal cytotoxic concentration: > 50000 nM
Compound 3 gave a limit, no number (the forecaster's own chance of this, stated with the estimate: 65%); the middle value lies on the limit itself.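

In this assay, for the compounds shown here, compound 1, compound 2 and compound 3 all stand at a limit, so no step among them can be read: the limit of > 50000 nM in this assay, at which 3 of the 3 values shown sit. Going by these compounds, how far the nitro, methoxy and phenyl compounds differ in this read-out stays open.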